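Swapping a benzyloxy for a phenyl at the pyridine core

The source may report more compounds than this note shows. Statements on the series, on what has been measured and on what is new or still open speak of the compounds shown alone.

Measured so far:
- compound 1, `Cc1cnn(-c2ccc(C)nc2C(=O)N2CC3(CC3)C[C@H]2CNc2ccc(C(F)(F)F)cn2)c1`, 8.9
- compound 2, `Cc1ccc(-c2nccs2)c(C(=O)N2CC3(CC3)C[C@H]2CNc2ccc(C(F)(F)F)cn2)n1`, 8.6
- compound 3, `Cc1ccc(OCc2ccccc2)c(C(=O)N2CC3(CC3)C[C@H]2CNc2ccc(C(F)(F)F)cn2)n1`, 8.6

All three compounds share the same core and differ only in the group attached to one aromatic carbon of the six-membered ring that carries the amide. In a functional assay on CHO cells for antagonist activity at Orexin/Hypocretin receptor type 1 (Homo sapiens), read by FLIPR and calcium flux (a lower number here means a less potent compound, a higher number a more potent compound, by a factor of ten per unit of this negative logarithm), compound 3 gives 8.6. It sits level with compound 2 at the digits shown, and the two together are the lowest of the three numbers; the step of a number 0.30 log units lower from compound 1 to compound 3 (within the scatter) and the step of no change at the digits printed from compound 2 to compound 3 (within the scatter) are both within the usual scatter, so no compound here can be called more or less potent than another.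

Compound 4, `Cc1ccc(-c2ccccc2)c(C(=O)N2CC3(CC3)C[C@H]2CNc2ccc(C(F)(F)F)cn2)n1`, has not been measured. The change from compound 3 is phenyl in place of benzyloxy on an aromatic carbon, placed ortho to a large group, two atoms from the ring nitrogen and para to a methyl group. Within the data shown here, the steps that bear on this are a number 0.30 log units lower from compound 1 to compound 2 (within the scatter) and no change at the digits printed from compound 2 to compound 3 (within the scatter), showing that a directly attached aromatic ring (compound 2) and a benzyloxy (compound 3) give the same number, and that the pyrazolyl of compound 1 is within scatter of both. A phenyl is another directly attached aromatic ring, so the expected step of no change at the digits printed from compound 3 to compound 4 (within the scatter) is none beyond the scatter. Compound 4 is therefore estimated at 8.6, with a range from 8.1 to 9.1.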

Compound 4, negative logarithm of the antagonist equilibrium constant: 8.6
Compound 4: middle estimate and measured number agree at the digits printed; measured number inside the range.
By their numbers in this assay, from the lowest: compounds 2, 3, 4 and 1 (each within the scatter of the next).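

In this assay, the step of no change at the digits printed from compound 3 to compound 4 (within the scatter) shows that a phenyl attached directly to the aromatic carbon can stand in for a benzyloxy, whose oxygen and extra carbon make no readable difference to the number here. The phenyl, a ring of carbon only, also compares closely with the 1,3-thiazol-2-yl, with no change at the digits printed from compound 2 to compound 4 (within the scatter), and with the 4-methyl-1H-pyrazol-1-yl, with a number 0.30 log units lower from compound 1 to compound 4 (within the scatter), so all four groups at this position lie within the scatter of one another in this assay. No measurement is available that explains this tolerance for such different groups.

On these data alone, all four groups contain an aromatic ring, so it remains open whether the number would hold with a group that has none, such as an amine, a carboxylic acid or a longer alkyl chain. Also open, as far as these compounds go, is whether a phenyl bearing a further group, such as a trifluoromethyl or a nitrile, would stay within the scatter of these four compounds or finally separate from them.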